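Aryl swap at the amine of compound 1

The source may hold more compounds than are shown below. What is called first, only, known or untested is meant among the compounds shown, and "the series" means these compounds.

Compound 1 `COc1ccc(CN[C@@H]2CO[C@H](C(c3ccccc3)c3ccccc3)C[C@H]2O)cc1O` gives 30.2 nM in an assay on Cerebral cortex for inhibition of Norepinephrine transporter (Rattus norvegicus) (on this read-out higher numbers stand for weaker inhibition and lower numbers for stronger inhibition), the highest of the three numbers measured; compound 3 `O[C@@H]1C[C@@H](C(c2ccc(F)cc2)c2ccc(F)cc2)OC[C@H]1NCc1ccc2c(c1)CCO2` gives 25.8 nM, within the scatter of compound 1, while compound 2 `Oc1ccc(CN[C@@H]2CO[C@H](C(c3ccc(F)cc3)c3ccc(F)cc3)C[C@H]2O)cc1F` gives 7.37 nM, beyond it. Compound 4 `COc1ccc(CN[C@@H]2CO[C@H](C(c3ccccc3)c3ccccc3)C[C@H]2O)cn1` carries 6-methoxypyridin-3-yl in place of 3-hydroxy-4-methoxyphenyl on a saturated chain carbon bound to an amine nitrogen. Among the measured compounds shown here, the only measured step at this position, a 3.5-fold higher number from compound 2 to compound 3 (0.54 log units; beyond the scatter), replaced a hydroxylated aryl with one lacking a hydrogen-bond donor and weakened binding modestly; the move from compound 1 to compound 4 also drops the single donor, so a step of similar size in the same direction is expected, though no measured pair shows a pyridine entering here. Compound 4 is therefore estimated at 75 nM, range 25 nM to 220 nM, a step of a 2.5-fold higher number from compound 1 to compound 4 (0.40 log units; beyond the scatter).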

Compound 4, inhibition constant: 38.1 nM
The estimate for compound 4 lay 2.0-fold (0.29 log units) above the measured number, and the stated range covers the measured number.
By their numbers in this assay, from the lowest: compound 2; then compounds 3, 1 and 4 (each within the scatter of the next).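

In this assay the step of a 1.3-fold higher number from compound 1 to compound 4 (0.10 log units; within the scatter) shows that 6-methoxypyridin-3-yl can replace 3-hydroxy-4-methoxyphenyl on the core of compound 1 without a change beyond the scatter, although the entering group has no hydrogen-bond donor. Loss of the donor therefore does not by itself give a step like a 3.5-fold higher number from compound 2 to compound 3 (0.54 log units; beyond the scatter), which lies beyond the scatter and starts from a different aryl pair. No measurement on hand explains this difference.

Still open, on these data alone, is whether 6-methoxypyridin-3-yl behaves the same way on the core of compound 2. Also open, as far as these compounds go, is how a carboxylic acid or a dimethylamino group in place of the methoxy would read.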